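A few compounds are considered here, and "the series" means these few. Any claim that something is new, unique, unknown or untested is made for them only; others in the source may bear on it.

Compound 1 `N[C@@H](CC(=O)NO)C(=O)O`: 15.8%
Compound 2 `N[C@@H](CS(N)(=O)=O)C(=O)O`: 25.8%
Compound 3 `N[C@@H](CS(=O)(=O)NCc1ccc(S(=O)(=O)F)cc1)C(=O)O`: 29.5%

Of the compounds shown here, three have been measured in an assay for inhibition of asparagine synthetase [glutamine-hydrolyzing] (Rattus norvegicus), with stated times of 15 min and 30 min, tested at 2 mM; a higher number here means more inhibition at the concentration tested (going by the name of the read-out), a lower number less inhibition. In this assay compound 1 gives 15.8%, compound 2 gives 25.8% and compound 3 gives 29.5%. Compound 2 stands second highest of the three numbers, but its gap to compound 3 and its gap to compound 1 both fall within the scatter of repeated measurements, so no order among the three can be read from these values.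

Compound 4 `N[C@@H](CS(=O)(=O)NO)C(=O)O` has not yet been measured. It differs from compound 2 in one place: hydroxy in place of hydrogen on a sulfonamide nitrogen. Among the measured compounds shown here, no step between two measured compounds in this assay is available, so nothing in the data tells how large a change of this kind is.

On that basis the expectation for compound 4 in this assay is a number close to that of compound 2, with the expected step of a number 2.2 percentage points higher from compound 2 to compound 4 (within the scatter) lying within the scatter, in no firm direction. Compound 4 is thus estimated at 28%, with a range from 12% to 45%.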

Compound 4, a percentage reported as inhibition, at one concentration (the size of the read-out at that concentration, not a potency): 96.5%
Beside the measured number, compound 4's estimate is 68.5 percentage points below it; measured number outside the range, above it.
By their numbers in this assay, from the lowest: compounds 1, 2 and 3 (each within the scatter of the next, the first and the last beyond it); then compound 4.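

In this assay the change from amino to hydroxyamino, hydroxy in place of hydrogen on a sulfonamide nitrogen, is a number 70.7 percentage points higher from compound 2 to compound 4 (beyond the scatter) and so gives the first single-place step available in this series. Among the compounds shown here, it shows that this nitrogen is a position where the addition of one oxygen atom can shift the read-out far beyond the scatter, which the earlier compounds, none a single-place neighbour of another, could not show. Nothing measured here bears on why this step is so large.

Going by these compounds, it remains open whether a methoxy or an amino group on the same sulfonamide nitrogen would give a comparable number. On these data alone, it is also open whether the gain would persist if the amine or the carboxylic acid of the shared core were replaced.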